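The source may hold more compounds than are shown below. What is called first, only, known or untested is meant among the compounds shown, and "the series" means these compounds.

Measured compounds in a functional assay on HeLa cells (Homo sapiens) for antiproliferative activity, read by CCK-8 assay, with a stated time of 48 h; a lower number here means a stronger inhibitor, a higher number a weaker inhibitor:
- compound 1, `COc1ccc(/C=C\c2cc(OC)c(OC)c(OC)c2)cc1OCc1ccc(C=O)cc1` — compound 1 gives 4800 nM.
- compound 2, `COc1ccc(/C=C\c2cc(OC)c(OC)c(OC)c2)cc1OCc1ccc(CN2CCCC[C@@H]2C(=O)O)cc1` — compound 2 sits at a limit of the assay, > 10000 nM.
- compound 3, `COc1ccc(/C=C\c2cc(OC)c(OC)c(OC)c2)cc1OCc1ccc(CN[C@H](C(=O)O)[C@H](C)O)cc1` — compound 3 also sits at a limit of the assay, > 10000 nM.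

Compound 1 is the only one of the three with a number; the other two values are limits, as described by the limit of > 10000 nM in this assay, at which 2 of the 3 values shown sit. The two measured steps from it both lead to such a limit: an at least 2.0-fold higher number from compound 1 to compound 2 (0.31 log units; beyond the scatter) and an at least 2.0-fold higher number from compound 1 to compound 3 (0.31 log units; beyond the scatter). The step between compound 2 and compound 3, a step that the two limits leave unreadable from compound 2 to compound 3, cannot be read.

Compound 4, `COc1ccc(/C=C\c2cc(OC)c(OC)c(OC)c2)cc1OCc1ccc(CN2CC[C@@H](C(=O)O)C2)cc1`, is not yet measured. It differs from compound 1 in one place: (3-carboxypyrrolidin-1-yl)methyl in place of formyl on an aromatic carbon. The change resembles those in compound 2 and compound 3, where a carboxylic-acid-bearing amine replaced the formyl group; both of those gave at least modest weakening in this assay. The same direction is therefore expected for compound 4, with the result likely again reported as a limit. The estimated step is a 3.1-fold higher number from compound 1 to compound 4 (0.49 log units; beyond the scatter). Compound 4 is expected at about 15000 nM, in the range 5000 nM to 40000 nM.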

Compound 4, half-maximal inhibitory concentration: 12800 nM
Beside the measured number, compound 4's estimate is 1.2-fold (0.07 log units) above it; the range from low to high includes it.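

In this assay, (3-carboxypyrrolidin-1-yl)methyl in place of formyl, on an aromatic carbon para to a large group, gives this kind of change a readable size: a 2.7-fold higher number from compound 1 to compound 4 (0.43 log units; beyond the scatter). Within the data shown here, compound 4 therefore shows a measured loss on replacing formyl with a carboxylic-acid-bearing amine, where the earlier steps gave only a minimum size. Compound 2 and compound 3 stay at a limit of the assay, so their steps to compound 4 cannot be read and the three amines cannot be ranked: the limit of > 10000 nM in this assay, at which 2 of the 4 values shown sit.

As far as these compounds go, it remains open whether the loss follows the carboxylic acid, the amine or the removal of formyl. A plain pyrrolidin-1-ylmethyl group without the carboxylic acid, or the methyl ester of compound 4, would help separate these.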